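The source may hold more compounds than are shown below. What is called first, only, known or untested is meant among the compounds shown, and "the series" means these compounds.

Measured so far in an ADME assay on HCT-116 cells (Homo sapiens) for cytotoxicity, read by CellTiter-Glo, with a stated time of 72 h; on this read-out lower numbers stand for stronger inhibition and higher numbers for weaker inhibition:
compound 1 `Cc1noc(C)c1S(=O)(=O)N1CCC(N2CCC(C)CC2)CC1`: > 10000 nM
compound 2 `CC1CCN(C2CCN(S(=O)(=O)c3ccc(-c4ccccc4F)cc3)CC2)CC1`: > 5000 nM

Both values are limits of this assay and not numbers. Compound 1 stands at the limit of > 10000 nM in this assay, at which 1 of the 2 values shown sits, with no number beneath it. Compound 2 stands at the limit of > 5000 nM in this assay, at which 1 of the 2 values shown sits. Neither compound reaches a measurable half-maximal inhibitory concentration, so compound 1 cannot be ordered against compound 2; the two values show only that both sit at the weak end of the range this assay covers.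

Compound 3 `CC1CCN(C2CCN(S(=O)(=O)c3ccc(Cl)c(Cl)c3)CC2)CC1` is not yet measured. It differs from compound 1 in one place: 3,4-dichlorophenyl in place of 3,5-dimethyl-1,2-oxazol-4-yl on a sulfonyl sulfur. Among the measured compounds shown here, no step between measured compounds is available to size this change, and neither measured value gives a number to build on. The expectation for compound 3 is that the step that the limit leaves unreadable from compound 1 to compound 3 stays within the scatter, so that this assay again reports only a limit. Compound 3 is thus estimated at 15000 nM, within a range from 4000 nM to 60000 nM, with a high chance that only a limit and no number is returned.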

Compound 3, half-maximal inhibitory concentration: > 5000 nM
Compound 3 was reported as a limit; the forecaster's own chance of this, stated with the estimate: 70%; the middle value does not contradict the limit.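

In this assay compound 3 gives > 5000 nM, a limit and not a number. Among the compounds shown here, compound 1 gives > 10000 nM, also a limit, so no step from compound 1 to compound 3 can be read. The compounds shown leave open whether 3,4-dichlorophenyl in place of 3,5-dimethyl-1,2-oxazol-4-yl on a sulfonyl sulfur alters cytotoxicity at all.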